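Extending the propyl chain on compound 1

The compounds below may be only part of what the source reports. "The series", "measured", "known", "first", "only" and "open" are said of these compounds alone.

Compound 1 `CCCc1ccc(N2C(=O)NC3(CSC4=C3C(=O)c3ncccc3C4=O)C2=O)cc1`: 1 nM in a functional assay on ACHN cells (Homo sapiens) for antiproliferative activity, read by MTT assay, with a stated time of 96 h; a higher number here means a weaker inhibitor, a lower number a stronger inhibitor
Compound 2 `COc1ccc(N2C(=O)NC3(CSC4=C3C(=O)c3ncccc3C4=O)C2=O)cc1`: 50 nM in this assay

Compound 1 stands lowest of the two numbers in this assay. Among the measured compounds shown here, the one measured step is a 50-fold higher number from compound 1 to compound 2 (1.70 log units; beyond the scatter), a large one. Compound 3 `CCCCc1ccc(N2C(=O)NC3(CSC4=C3C(=O)c3ncccc3C4=O)C2=O)cc1` differs from compound 1 by methyl in place of hydrogen on a saturated chain carbon, three bonds along the chain from an aromatic carbon. For the measured compounds named here, that measured step exchanges one group for another of a different kind, so it bears only loosely on lengthening the chain by one carbon; no measured pair changes chain length alone. With so little to go on, a step within the scatter is expected, a 2.0-fold higher number from compound 1 to compound 3 (0.30 log units; within the scatter). Compound 3 is estimated at 2 nM, between 0.5 nM and 10 nM.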

Compound 3, half-maximal inhibitory concentration: 50 nM
Beside the measured number, compound 3's estimate is 25-fold (1.40 log units) below it, outside the stated range (above it).
By their numbers in this assay, from the lowest: compound 1; then compounds 2 and 3 (each within the scatter of the next).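

In this assay, the position turns out to be sensitive to a single carbon: going from propyl to butyl, with methyl in place of hydrogen three bonds along the chain from an aromatic carbon, gives a 50-fold higher number from compound 1 to compound 3 (1.70 log units; beyond the scatter) and so removes the advantage of compound 1. Butyl and methoxy cannot be told apart here, with no change at the digits printed from compound 2 to compound 3 (within the scatter) as the step between them. Nothing available explains why one added carbon matters so much.

Going by these compounds, whether a pentyl chain would raise the number further remains open. So does whether a shorter ethyl chain or a branched isopropyl group would match compound 1.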